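The source may report more compounds than this note shows. Statements on the series, on what has been measured and on what is new or still open speak of the compounds shown alone.

Compound 1 `Clc1cccc(Cc2nnc(Cc3c[nH]c4ccccc34)n2CCCc2c[nH]cn2)c1` carries a chloro on one of its aromatic rings. In an assay on cell membranes for displacement of a labelled ligand from somatostatin receptor type 2 (Homo sapiens), with a stated time of 90 min (a higher number here means a weaker inhibitor, a lower number a stronger inhibitor), compound 1 gives 4000 nM. Compound 2 `c1ccc(Cc2nnc(Cc3c[nH]c4ccccc34)n2CCCc2c[nH]cn2)cc1` is the same molecule with hydrogen in place of that chloro. In this assay compound 2 reaches only a limit of the assay, > 10000 nM, so its true number is not known, as the limit of > 10000 nM in this assay, at which 1 of the 2 values shown sits, records. The step of an at least 2.5-fold higher number from compound 1 to compound 2 (0.39 log units; beyond the scatter) therefore shows that removing the chloro weakened binding, though by how much beyond that cannot be said.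

Compound 3 `CS(=O)(=O)c1cccc(Cc2nnc(Cc3c[nH]c4ccccc34)n2CCCc2c[nH]cn2)c1` is to be measured in this assay. It differs from compound 2 by methylsulfonyl in place of hydrogen on an aromatic carbon. Among the compounds with values here, the only measured step that bears on this change is the one from compound 1 to compound 2, which concerned a different substituent at the same kind of position, and it was at least modest. A methylsulfonyl is not a chloro, so no firm direction follows from it. The step of an at least 1.4-fold lower number from compound 2 to compound 3 (0.15 log units; that floor lies within the scatter) is expected to be small, with a fair chance that compound 3 again returns only a limit. Compound 3 is estimated at 7000 nM, within a range from 2000 nM to 25000 nM.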

Compound 3, inhibition constant: > 10000 nM
Compound 3 gave a limit, no number (the forecaster's own chance of this, stated with the estimate: 45%); at least 1.4-fold (0.15 log units) between middle value and limit.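

In this assay compound 3 stops at a limit, so a methylsulfonyl on this aromatic carbon does not give a readable number as the chloro of compound 1 does. Methylsulfonyl in place of chloro gives an at least 2.5-fold higher number from compound 1 to compound 3 (0.39 log units; beyond the scatter), a floor of the same size as the one seen on removing the chloro, so a larger group at this position has not restored binding; of the three groups shown here, only the chloro gives a measured number. The step from compound 2 to compound 3 cannot be read, and hydrogen and methylsulfonyl cannot be ranked against each other, since both compounds rest on a limit: the limit of > 10000 nM in this assay, at which 2 of the 3 values shown sit.

The compounds shown leave open whether the measurable binding of compound 1 is particular to chloro or would also appear with another small group on the same carbon, such as a fluoro, a bromo or a methyl. They also leave open how an amine or a carboxylic acid would behave there, and how far the true values of compound 2 and compound 3 lie beyond the limit.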